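The compounds below may be only part of what the source reports. "The series", "measured", "known", "first", "only" and "open" are said of these compounds alone.

In a functional assay on HepG2 cells (Homo sapiens) for cytotoxicity, read by MTT assay, with a stated time of 24 h (a higher number here means a weaker inhibitor, a lower number a stronger inhibitor), compound 1 (`O=Cc1ccc(O)c(C(=O)Nc2ccc(C(F)(F)F)cc2)c1`) gives 17600 nM and compound 2 (`CC(=O)c1ccc(NC(=O)c2cc(Br)ccc2O)cc1`) gives 15900 nM. Within the data shown here, these two values lie within the scatter of each other, so compound 2 stands level with the only other measured compound. Compound 3 (`O=C(Nc1ccc(C(F)(F)F)cc1)c1cc(Br)ccc1O`) follows from compound 2 with trifluoromethyl in place of acetyl on an aromatic carbon, para to a large group: trifluoromethyl in place of acetyl on an aromatic carbon. Among the measured compounds shown here, no measured pair isolates this change, so its size in this assay can only be expected, and no step beyond the scatter is expected in either direction. This expectation rests on compound 1, which carries trifluoromethyl and gives 17600 nM. The estimated step is a 1.2-fold lower number from compound 2 to compound 3 (0.09 log units; within the scatter). For compound 3 the estimated value is 13000 nM, with an expected range of 5500 nM to 30000 nM.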

Compound 3, half-maximal inhibitory concentration: 5500 nM
The estimate for compound 3 lay 2.4-fold (0.37 log units) above the measured number; the range from low to high includes it.
By their numbers in this assay, from the lowest: compound 3; then compounds 2 and 1 (each within the scatter of the next).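

Among these compounds, on an aromatic carbon, para to a large group, trifluoromethyl in place of acetyl gives a 2.9-fold lower number from compound 2 to compound 3 (0.46 log units; beyond the scatter) in this assay, the first sign that the group at this position affects the read-out; compounds 1 and 2 differ in two places and could not isolate this. The second step, bromo in place of formyl on an aromatic carbon, gives a 3.2-fold lower number from compound 1 to compound 3 (0.51 log units; beyond the scatter), so compound 3 combines bromo and trifluoromethyl, and a single swap of either group gives a higher number. No measured property of these compounds is available to account for either step.

As far as these compounds go, whether other groups at the para position, such as a nitrile, an amine or a carboxylic acid, would follow trifluoromethyl or acetyl remains open. Also open, from the compounds shown here alone, is how a chloro or a methoxy would compare with bromo.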